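Dichlorobenzyl swap on two related cores

The compounds below may be only part of what the source reports. "The series", "measured", "known", "first", "only" and "open" are said of these compounds alone.

In a functional assay on CNE2Z cells (Homo sapiens) for inhibition, read by MTT assay, with a stated time of 72 h (a lower number here means a stronger inhibitor, a higher number a weaker inhibitor), compound 1 `C=CCc1ccc(O)c(-c2ccc(OCc3ccc(Cl)c(Cl)c3)c(CC=C)c2)c1` gives 17800 nM. Compound 2 `C=CCc1ccc(O)c(-c2ccc(OCc3c(Cl)cccc3Cl)c(CC=C)c2)c1` carries 2,6-dichlorophenyl in place of 3,4-dichlorophenyl on a saturated chain carbon bound to an oxygen on an aromatic ring relative to compound 1; in this assay compound 2 gives 16400 nM, and the step is a 1.1-fold lower number from compound 1 to compound 2 (0.04 log units; within the scatter). Compound 3 `C=CCc1ccc(OCc2ccc(Cl)c(Cl)c2)c(-c2ccc(O)c(CC=C)c2)c1` bears the same dichlorobenzyl ether on a different core; the difference between the two cores is not broken down here. In this assay compound 3 gives 14200 nM. The three numbers all sit within the usual scatter of one another, so no order among them can be read. Compound 4 `C=CCc1ccc(OCc2c(Cl)cccc2Cl)c(-c2ccc(O)c(CC=C)c2)c1` is not yet measured; it relates to compound 3 as compound 2 relates to compound 1, carrying (2,6-dichlorophenyl in place of 3,4-dichlorophenyl on a saturated chain carbon bound to an oxygen on an aromatic ring), the same change at the same place. Because the earlier swap gave a 1.1-fold lower number from compound 1 to compound 2 (0.04 log units; within the scatter), a step of similar size, a 1.1-fold lower number from compound 3 to compound 4 (0.04 log units; within the scatter), is expected here. Compound 4 is estimated at 13000 nM in this assay, with a likely range from 6000 nM to 28000 nM.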

Compound 4, half-maximal inhibitory concentration: 19900 nM
For compound 4 the middle estimate is 1.5-fold (0.18 log units) below the measured one, within the range that was stated.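

In this assay, the swap from 3,4-dichlorobenzyl to 2,6-dichlorobenzyl on the core of compound 3 gives a 1.4-fold higher number from compound 3 to compound 4 (0.15 log units; within the scatter). Set beside the earlier step, the change shows no detectable dependence on the core: the same change on two cores in this assay, a 1.1-fold lower number (0.04 log units; within the scatter) from compound 1 to compound 2 and a 1.4-fold higher number (0.15 log units; within the scatter) from compound 3 to compound 4, 1.5-fold (0.18 log units) apart, within the scatter of two such steps. Going by these compounds alone, this shows only that neither step stands out from the scatter; it does not establish that the swap acts identically on both cores, that either dichlorobenzyl group is preferred, or that the opposite directions of the two steps are real.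

Open, going by these compounds, is whether any change to the benzyl group moves the number beyond the scatter on either core. An amine or a carboxylic acid in place of the chlorines would test this.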